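Fluoro for methyl beside the acid-bearing ring

The source may report more compounds than this note shows. Statements on the series, on what has been measured and on what is new or still open speak of the compounds shown alone.

Compound 1 `CCC(Oc1ccc(OCc2cccc(-c3c(C)cc(OCCCS(C)(=O)=O)cc3C)c2)cc1)C(=O)O` is recorded in a functional assay on CHO cells for agonist activity at Free fatty acid receptor 1 (Homo sapiens), read by fluorescence and calcium flux (a higher number here means that more compound is needed for the effect, a lower number that less compound is needed), as "not determined" (no result reported). For the measured compounds named here, compound 2 `Cc1cc(OCc2cccc(-c3c(C)cc(OCCCS(C)(=O)=O)cc3C)c2)ccc1OCC(=O)O` gives 153 nM in this assay, the only number available, so it stands alone as the reference point. Compound 3 `Cc1cc(OCCCS(C)(=O)=O)cc(C)c1-c1cccc(COc2ccc(OCC(=O)O)c(F)c2)c1` differs from compound 2 by one exchange: fluoro in place of methyl on an aromatic carbon, a fluoro in place of methyl on an aromatic carbon. Going by the values given here, no measured pair shows such a step, so the expected change is small, from compound 2 to compound 3 estimated as a 1.3-fold higher number from compound 2 to compound 3 (0.12 log units; within the scatter), within or near the scatter. Compound 3 is expected to give about 200 nM, with a likely range from 60 nM to 700 nM.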

Compound 3, half-maximal effective concentration: 62.3 nM
For compound 3 the middle estimate is 3.2-fold (0.51 log units) above the measured one, within the range that was stated.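

In this assay the exchange of methyl for fluoro gives a 2.5-fold lower number from compound 2 to compound 3 (0.39 log units; beyond the scatter) on the ring bearing the carboxymethoxy group. This position, ortho to that group, therefore does not depend on methyl, and the smaller fluoro-bearing 4-(carboxymethoxy)-3-fluorophenyl group gives the lower number. Nothing at hand accounts for the step.

From the compounds shown here alone, whether chloro, methoxy or plain hydrogen at this same position would give a lower number still remains open. So does whether the step would carry over if a longer acid chain replaced the carboxymethoxy group.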